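A few compounds are considered here, and "the series" means these few. Any claim that something is new, unique, unknown or untested is made for them only; others in the source may bear on it.

Within the data shown here, compound 1 `c1ccc(-c2ccccc2OCCn2ccnc2)cc1` is the only compound with a number in a functional assay on the whole organism with Mus musculus as the target (on this read-out higher numbers stand for an effect only at larger amounts of compound and lower numbers for an effect already at smaller amounts), where compound 1 gives 320 mg/kg. Compound 2 `c1ccc(-c2ccccc2OCCCn2ccnc2)cc1` returned only a limit of the assay in this assay, > 280 mg/kg. Among the measured compounds shown here, that leaves a step that the limit leaves unreadable from compound 1 to compound 2 unreadable; the one piece of evidence is the limit of > 280 mg/kg in this assay, at which 1 of the 2 values shown sits. Compound 3 `c1ccc(OCCn2ccnc2)cc1` differs from compound 1 by hydrogen in place of phenyl on an aromatic carbon. For the measured compounds named here, no measured step touches the phenyl, so for compound 3 a step no larger than the usual scatter is expected, no change at the digits printed from compound 1 to compound 3 (within the scatter). Compound 3 is accordingly estimated at 320 mg/kg, within a range from 140 mg/kg to 750 mg/kg.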

Compound 3, dose for half-maximal effect: > 280 mg/kg
Compound 3: no number, only a limit; the forecaster's own chance of this, stated with the estimate: 35%; the middle value is on the limit's open side.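

Compound 3 returned only a limit in this assay, so the change from compound 1 to compound 3 cannot be read as a step. The compounds shown leave open how far compound 2 and compound 3 actually lie from compound 1.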